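2-Carboxyphenyl in place of 2-carboxyethyl: working notes

The source may report more compounds than this note shows. Statements on the series, on what has been measured and on what is new or still open speak of the compounds shown alone.

In a functional assay on HepG2 cells (Homo sapiens) for antiproliferative activity, read by MTT assay, with a stated time of 72 h (a higher number here means a weaker inhibitor, a lower number a stronger inhibitor), compound 1 (`O=C(O)CCC(=O)OCCOc1no[n+]([O-])c1S(=O)(=O)c1ccccc1`) gives > 10000 nM as a limit, not a number. Compound 2 (`O=C(O)CCCC(=O)OCCCOc1no[n+]([O-])c1S(=O)(=O)c1ccccc1`) gives > 10000 nM as a limit too. Going by the values given here, compound 1 therefore offers no number to count from, and the series so far shows only the limit of > 10000 nM in this assay, at which 2 of the 2 values shown sit, as its evidence. Compound 3 (`O=C(O)c1ccccc1C(=O)OCCOc1no[n+]([O-])c1S(=O)(=O)c1ccccc1`) carries 2-carboxyphenyl in place of 2-carboxyethyl on a carbonyl carbon. Among the compounds with values here, no measured step gives a size for this change. In this assay a small step toward a stronger inhibitor is expected, possibly none beyond the scatter. The estimate means an at least 1.1-fold lower number from compound 1 to compound 3 (0.04 log units; that floor lies within the scatter) as an expected step. In this assay compound 3 is estimated at 9000 nM (expected range 2500 nM to 30000 nM).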

Compound 3, half-maximal inhibitory concentration: > 10000 nM
Compound 3: no number, only a limit; the forecaster's own chance of this, stated with the estimate: 55%; at least 1.1-fold (0.04 log units) between middle value and limit.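

Compound 1 and compound 3 both stand only as limits in this assay, so no step can be read between them. The compounds shown leave open what 2-carboxyphenyl in place of 2-carboxyethyl does to the inhibitory concentration.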